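The source may hold more compounds than are shown below. What is called first, only, known or untested is meant among the compounds shown, and "the series" means these compounds.

Going by the values given here, compound 2 `O=C(Nc1ccc(Oc2ccnc3[nH]ccc23)c(F)c1)c1nn(-c2ccccc2)ccc1=O` is the only compound with a number in a functional assay on HepG2 cells (Homo sapiens) for cytotoxicity, read by MTT assay, with a stated time of 72 h; on this read-out lower numbers stand for stronger inhibition and higher numbers for weaker inhibition: compound 2 gives 24900 nM. Compound 1 `COc1ccc(-n2ccc(=O)c(C(=O)Nc3ccc(Oc4ccnc5[nH]ccc45)c(F)c3)n2)cc1` reports only a limit in this assay, namely > 60000 nM. Among the compounds with values here, the one measured step, an at least 2.4-fold lower number from compound 1 to compound 2 (0.38 log units; beyond the scatter), puts hydrogen on an aromatic carbon where methoxy stood. Compound 3 `Cn1ccc2c(Oc3ccc(NC(=O)c4nn(-c5ccccc5)ccc4=O)cc3F)ccnc21` differs from compound 2 by methyl in place of hydrogen on an aromatic nitrogen, a change at another place, so that step bears on it only loosely. No shift beyond the scatter is expected, and the estimated step is a 1.0-fold higher number from compound 2 to compound 3 (0.00 log units; within the scatter). Compound 3 is expected to give 25000 nM, between 8000 nM and 80000 nM.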

Compound 3, half-maximal inhibitory concentration: > 60000 nM
Compound 3 ended at the assay's limit (the forecaster's own chance of this, stated with the estimate: 30%); at least 2.4-fold (0.38 log units) between middle value and limit.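

Methyl in place of hydrogen on the aromatic nitrogen, a place where the earlier compounds carried no change, shifts the result in this assay beyond the scatter: an at least 2.4-fold higher number from compound 2 to compound 3 (0.38 log units; beyond the scatter). This place therefore matters too, and of the two groups tried here, hydrogen goes with the stronger inhibition. The value of compound 3 is a limit and not a number, so the true size of this step stays unknown: the limit of > 60000 nM in this assay, at which 2 of the 3 values shown sit.

Still open, as far as these compounds go, is how an ethyl group, a longer chain or an acetyl group on this nitrogen would read. Also open, from the compounds shown here alone, is whether methyl here would have the same effect alongside the methoxy group of compound 1.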